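Swapping propylsulfanyl for methoxy on the shared core

The source may report more compounds than this note shows. Statements on the series, on what has been measured and on what is new or still open speak of the compounds shown alone.

Measured in a functional assay on the whole organism with Mus musculus as the target; on this read-out lower numbers stand for an effect already at smaller amounts and higher numbers for an effect only at larger amounts of compound:
- compound 1 `Cc1c(C)c2c(c(C)c1N)CC(C)(C)O2`: 7.8 mg/kg
- compound 2 `Cc1c(C)c2c(c(C)c1N)CC(C)(CSc1ccncc1)O2`: 19.9 mg/kg
- compound 3 `CCCSCC1(C)Cc2c(C)c(N)c(C)c(C)c2O1`: 24.6 mg/kg

Compound 3 stands at the upper end of this small set. The data show a 1.2-fold higher number from compound 2 to compound 3 (0.09 log units; within the scatter), and also a 3.2-fold higher number from compound 1 to compound 3 (0.50 log units; beyond the scatter). Compound 4 `COCC1(C)Cc2c(C)c(N)c(C)c(C)c2O1` carries methoxy in place of propylsulfanyl on a saturated chain carbon bound to a saturated ring carbon. Going by the values given here, no compound with methoxy has been measured, so the nearest guides are the steps that put sulfur groups on compound 1: a 3.2-fold higher number from compound 1 to compound 3 (0.50 log units; beyond the scatter) and a 2.6-fold higher number from compound 1 to compound 2 (0.41 log units; beyond the scatter). Compound 4 is therefore expected to fall part of the way back. The expected change in this assay is a 1.8-fold lower number from compound 3 to compound 4 (0.24 log units; within the scatter), a small step towards a lower number. For compound 4 the estimated value is 14 mg/kg, with an expected range of 6 mg/kg to 30 mg/kg.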

Compound 4, dose for 50% inhibition: 20.1 mg/kg
Estimate against measurement, compound 4: 1.4-fold (0.16 log units) below; measured number inside the range.
By their numbers in this assay, from the lowest: compound 1; then compounds 2, 4 and 3 (each within the scatter of the next).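

With methoxy on this saturated chain carbon, this assay gives a 1.2-fold lower number from compound 3 to compound 4 (0.09 log units; within the scatter) and a 1.0-fold higher number from compound 2 to compound 4 (0.00 log units; within the scatter), so the sulfur atom and the larger propyl and pyridin-4-yl groups are not needed to reach this level. Even methoxy, with only two heavy atoms, shows a 2.6-fold higher number from compound 1 to compound 4 (0.41 log units; beyond the scatter), so all three groups shown here give higher numbers than hydrogen. Nothing available explains why these three groups read alike. Still open, from the compounds shown here alone, is whether an amine, a carboxylic acid or a hydroxyl group at this place would bring the number back towards that of compound 1.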